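The source may report more compounds than this note shows. Statements on the series, on what has been measured and on what is new or still open speak of the compounds shown alone.

Compound 2 `Cc1nnc(S)n2c(C)nc(C)c12` stands at the edge of what a functional assay for inhibition, with Homo sapiens as the target (a higher number here means a weaker inhibitor, a lower number a stronger inhibitor), can report: compound 2 gives > 48000 nM, a limit of the assay rather than a number. Compound 3 `CSc1nnc(C)c2c(C)nc(C)n12` gives > 48000 nM in this assay, again a limit. Compound 1 `CCCc1nc(C)c2c(CC)nnc(S)n12` gives > 48000 nM in this assay, also a limit. Among the measured compounds shown here, the single measured step, a step that the two limits leave unreadable from compound 2 to compound 3, cannot be sized, since (the limit of > 48000 nM in this assay, at which 3 of the 3 values shown sit). Compound 4 `CCCc1nc(C)c2c(C)nnc(S)n12` differs from compound 2 by ethyl in place of hydrogen on a saturated chain carbon bound to an aromatic carbon. No readable step bears on this change; the three values shown all sit at the limit. Compound 4 is therefore expected to remain at or near the limit, the step that the limit leaves unreadable from compound 2 to compound 4 being an estimate only. For compound 4 the estimate is 80000 nM, with a range from 20000 nM to 400000 nM.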

Compound 4, half-maximal inhibitory concentration: 45000 nM
Compound 4: middle estimate off by 1.8-fold (0.25 log units), on the high side; the range from low to high includes it.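

Among the compounds shown here, compound 4 is the first to give a readable number in this assay, so methyl to propyl on a saturated chain carbon bound to an aromatic carbon now has one end off the limit. That change reads as an at least 1.0-fold lower number from compound 2 to compound 4 (0.02 log units; that floor lies within the scatter), so no gain can be claimed for the propyl. Hydrogen in place of methyl on a saturated chain carbon bound to an aromatic carbon reads as an at least 1.0-fold lower number from compound 1 to compound 4 (0.02 log units; that floor lies within the scatter), again only a floor.

As far as these compounds go, the true distance of compound 1 and compound 2 from compound 4 stays open, as both are known only as limits. From the compounds shown here alone, whether a longer chain or an amine at this carbon gives a value clearly clear of the limit also stays open.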